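Series notes: the step from compound 1 to compound 4

The compounds below may be only part of what the source reports. "The series", "measured", "known", "first", "only" and "open" are said of these compounds alone.

Measured compounds:
- compound 1, `CC(C)(C)N(NC(=O)c1ccccc1I)C(=O)c1ccccc1Cl`: 1290 nM
- compound 2, `CC(C)(C)N(NC(=O)c1ccc(Cl)cc1)C(=O)c1ccccc1Cl`: 115 nM
- compound 3, `CCCc1ccc(C(=O)NN(C(=O)c2ccccc2Cl)C(C)(C)C)cc1`: 9.12 nM

In an assay on cells for agonist activity at ecdysone receptor (Bombyx mori), read by a luciferase reporter, with a stated time of 24 h (a higher number here means that more compound is needed for the effect, a lower number that less compound is needed), compound 1 gives 1290 nM, the highest number of the three measured compounds. The nearest is compound 2 at 115 nM, the furthest compound 3 at 9.12 nM. The step of an 11-fold lower number from compound 1 to compound 2 (1.05 log units; beyond the scatter) arises from the change of the 2-iodophenyl on the carbonyl carbon to 4-chlorophenyl; the step of a 13-fold lower number from compound 2 to compound 3 (1.10 log units; beyond the scatter) then follows on the same ring.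

Compound 4, `COc1ccc(C(=O)NN(C(=O)c2ccccc2Cl)C(C)(C)C)cc1`, is not yet measured in this assay. It differs from compound 1 by 4-methoxyphenyl in place of 2-iodophenyl on a carbonyl carbon.

The step from compound 1 to compound 2 bears most directly on this change, since both replace the 2-iodophenyl with a ring carrying a group at the 4-position. Going by the values given here, the step from compound 2 to compound 3 shows that the nature of that group matters, but no measured compound carries a methoxy, so its weight is uncertain. A lower number is therefore expected for compound 4 than for compound 1, of a size roughly like the first step: the estimated step is an 8.6-fold lower number from compound 1 to compound 4 (0.93 log units; beyond the scatter), giving an expected value of 150 nM, with a range from 40 nM to 600 nM.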

Compound 4, half-maximal effective concentration: 51.3 nM
The estimate for compound 4 lay 2.9-fold (0.47 log units) above the measured number; low and high end bracket the measured number.
By their numbers in this assay, from the lowest: compound 3; then compound 4; then compound 2; then compound 1.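

In this assay, replacing the 2-iodophenyl on the carbonyl carbon with 4-methoxyphenyl gives a 25-fold lower number from compound 1 to compound 4 (1.40 log units; beyond the scatter), so this change reaches further than the switch to 4-chlorophenyl did. With the rest of the structure held constant, methoxy in place of chloro gives a 2.2-fold lower number from compound 2 to compound 4 (0.35 log units; beyond the scatter), a modest step beyond the scatter, while methoxy in place of propyl gives a 5.6-fold higher number from compound 3 to compound 4 (0.75 log units; beyond the scatter), so the group on this aromatic carbon changes the number and propyl keeps the lower one. No measurement available here explains these differences.

The compounds shown cannot separate the identity of the group from its location on the ring, since the 2-iodophenyl differs from each other ring in both. On these data alone, how an amine, a carboxylic acid or a butyl chain on this aromatic carbon would compare with propyl and methoxy remains open.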